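A few compounds are considered here, and "the series" means these few. Any claim that something is new, unique, unknown or untested is made for them only; others in the source may bear on it.

Compound 1 `[O-][S+](Cc1cc(Br)cs1)C(c1ccccc1)c1ccccc1`: 13700 nM
Compound 2 `O=c1[nH]nc(C[S+]([O-])C(c2ccccc2)c2ccccc2)s1`: 38100 nM

In an assay on HEK293 cells for inhibition of sodium-dependent dopamine transporter (Homo sapiens), read by scintillation counting, with stated times of 5 min and 1 min (a higher number here means a weaker inhibitor, a lower number a stronger inhibitor), compound 2 gives the higher of the two numbers; the step of a 2.8-fold higher number from compound 1 to compound 2 (0.44 log units; beyond the scatter) lies beyond the scatter. Compound 3 `Cc1nc(O)cc(C[S+]([O-])C(c2ccccc2)c2ccccc2)n1` differs from compound 2 in one place: a group of 8 heavy atoms (5 carbon, 2 nitrogen, 1 oxygen; one six-membered aromatic ring with 2 hetero atoms) in place of a group of 6 heavy atoms (2 carbon, 2 nitrogen, 1 oxygen, 1 sulfur; one five-membered aromatic ring with 3 hetero atoms), on a saturated chain carbon bound to a sulfur. Going by the values given here, the only measured step that bears on this position is a 2.8-fold higher number from compound 1 to compound 2 (0.44 log units; beyond the scatter), which shows that exchanging the aromatic ring on that carbon moves the read-out modestly. Among the compounds with values here, no measured step leads to a six-membered ring here, so only a modest shift in either direction is expected. For compound 3 the expected step is a 1.3-fold lower number from compound 2 to compound 3 (0.10 log units; within the scatter). Compound 3 is therefore estimated at 30000 nM, with a range from 8000 nM to 100000 nM.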

Compound 3, half-maximal inhibitory concentration: 3100 nM
Compound 3: the middle estimate sits 9.7-fold (0.99 log units) above what was measured; measured number outside the range, below it.
By their numbers in this assay, from the lowest: compound 3; then compound 1; then compound 2.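

In this assay, the group on the saturated chain carbon bound to a sulfur can change the read-out far more than the earlier pair suggested: 6-hydroxy-2-methylpyrimidin-4-yl brings a large gain (with a 12-fold lower number from compound 2 to compound 3 (1.09 log units; beyond the scatter)) and a smaller one against 4-bromothiophen-2-yl (with a 4.4-fold lower number from compound 1 to compound 3 (0.65 log units; beyond the scatter)). The groups exchanged between compound 2 and compound 3 have equal counts of hydrogen-bond donors and acceptors, yet the numbers differ widely. No available evidence explains this gain.

Still open, from the compounds shown here alone, is whether the hydroxy or the methyl on the pyrimidine ring matters more. An amine in place of that hydroxy could help separate their contributions.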